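This account rests on a few compounds, and the source may have more. Where it says the series, first, only, none or still open, it means among the compounds named here.

Measured compounds:
- compound 1, `CCCc1cc(NC2CCC2)c2cc(NC(=O)/C=C/c3ccc(C(F)(F)F)cc3)ccc2n1`, 270 nM in a functional assay on HEK293 cells for activation of melanin-concentrating hormone receptor 1 (Homo sapiens), read by inositol phosphate accumulation; a lower number here means that less compound is needed, a higher number that more compound is needed for the effect
- compound 2, `CCCc1cc(N2CCCC2)c2cc(NC(=O)/C=C/c3ccc(C(F)(F)F)cc3)ccc2n1`, 2800 nM
- compound 3, `CCCc1cc(NC)c2cc(NC(=O)/C=C/c3ccc(C(F)(F)F)cc3)ccc2n1`, 150 nM

The three share one core and differ only in the amine group on the aromatic carbon. Compound 3, with a methylamino group, gives the smallest number, but the step between them is only a 1.8-fold lower number from compound 1 to compound 3 (0.26 log units; within the scatter), so the two cannot be told apart. Compound 2, the only one whose amine nitrogen carries no hydrogen, stands clearly apart: a 10-fold higher number from compound 1 to compound 2 (1.02 log units; beyond the scatter) and a 19-fold lower number from compound 2 to compound 3 (1.27 log units; beyond the scatter).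

Compound 4, `CCCc1cc(N(C)C)c2cc(NC(=O)/C=C/c3ccc(C(F)(F)F)cc3)ccc2n1`, is the next step from compound 3: methyl in place of hydrogen on a nitrogen on an aromatic ring. As with compound 2, the nitrogen then carries two carbon groups and no hydrogen. Among the measured compounds shown here, the one measured step that bears on this, from a secondary to a tertiary amine, is a 10-fold higher number from compound 1 to compound 2 (1.02 log units; beyond the scatter), a large rise in the number. Whether the two methyl groups of compound 4 behave like the ring of compound 2 is not known from these data, but the same direction seems the better bet, perhaps with a smaller size. Compound 4 is therefore expected to need more compound than compound 3, with an estimated step of a 6.0-fold higher number from compound 3 to compound 4 (0.78 log units; beyond the scatter), giving an estimate of 900 nM with a range from 250 nM to 3500 nM in this assay.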

Compound 4, half-maximal effective concentration: 300 nM
Compound 4: middle estimate off by 3.0-fold (0.48 log units), on the high side; low and high end bracket the measured number.
By their numbers in this assay, from the lowest: compounds 3, 1 and 4 (each within the scatter of the next); then compound 2.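

In this assay, putting a methyl on the nitrogen of compound 3 gives a 2.0-fold higher number from compound 3 to compound 4 (0.30 log units; within the scatter), and the exchange of cyclobutylamino for dimethylamino gives a 1.1-fold higher number from compound 1 to compound 4 (0.05 log units; within the scatter), so compounds 1, 3 and 4 cannot be told apart. This shows that an amine nitrogen with no hydrogen does not by itself set a compound apart: compound 4 has no hydrogen there and still sits with compounds 1 and 3, so compound 2 is the only one of the four that stands clearly apart, with a 9.3-fold lower number from compound 2 to compound 4 (0.97 log units; beyond the scatter). Dimethylamino and pyrrolidin-1-yl therefore differ clearly at this position, but no measurement here offers an explanation for that difference.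

The compounds shown leave open whether the high number of compound 2 belongs to ring-closed amines in general, which a piperidin-1-yl or azetidin-1-yl group would test, or whether an open diethylamino group would also move away from dimethylamino. They also leave open how a plain amino group, with no carbon group on the nitrogen, would compare with methylamino in this series.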